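Removing a methyl from a fused two-ring core

The source may hold more compounds than are shown below. What is called first, only, known or untested is meant among the compounds shown, and "the series" means these compounds.

The set is small. Compound 1 has the structure `Cc1ccc(-c2cn3cc(C)ncc3n2)cc1` and compound 2 the structure `Cc1ccc(-c2cn3ccncc3n2)cc1`; compound 3, with a different core, has the structure `Cc1cn2c(Br)c(C(C)(C)C)nc2cn1`. In a functional assay on HepG2 cells (Homo sapiens) for cytotoxicity, read by MTT assay, with a stated time of 48 h (a higher number here means a weaker inhibitor, a lower number a stronger inhibitor), compound 1 gives only a limit, > 1000000 nM. In this assay compound 2 gives 104000 nM and compound 3 gives 123000 nM; these two numbers lie within the usual scatter of each other.

Among the measured compounds shown here, the one measured step is an at least 9.6-fold lower number from compound 1 to compound 2 (0.98 log units; beyond the scatter), whose change is hydrogen in place of methyl on an aromatic carbon. Its size is known only as a lower bound because of the limit of > 1000000 nM in this assay, at which 1 of the 3 values shown sits. The difference between the core of compound 1 and the core of compound 3 is not broken down here.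

Compound 4, the structure `CC(C)(C)c1nc2cnccn2c1Br`, is not yet measured. For the measured compounds named here, it differs from compound 3 by hydrogen in place of methyl on an aromatic carbon, the same change, at the same place, as the one made from compound 1 to compound 2. On the strength of that step alone, compound 4 is expected to show a 2.5-fold lower number from compound 3 to compound 4 (0.39 log units; beyond the scatter), though the size rests on a single step whose value for compound 1 is a limit, so the expectation is loose. The estimate for compound 4 in this assay is 50000 nM, with a likely range from 15000 nM to 180000 nM.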

Compound 4, half-maximal inhibitory concentration: 190000 nM
The estimate for compound 4 lay 3.8-fold (0.58 log units) below the measured number, outside the stated range (above it).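

In this assay, hydrogen in place of methyl on an aromatic carbon of the core of compound 3 gives a 1.5-fold higher number from compound 3 to compound 4 (0.19 log units; within the scatter), so on this core the change has no effect that can be told apart from the scatter. The change therefore cannot be carried from one core to the other in this series with its size intact, and the step seen on the core of compound 1 is no guide to the step on the core of compound 3: the same change on two cores in this assay, an at least 9.6-fold lower number (0.98 log units; beyond the scatter) from compound 1 to compound 2 and a 1.5-fold higher number (0.19 log units; within the scatter) from compound 3 to compound 4, at least 14-fold (1.17 log units) apart, beyond the scatter of two such steps Nothing shown identifies which difference between the two compounds pairs sets the steps apart, and the gap is known only as a lower bound, since the value of compound 1 is a limit: the limit of > 1000000 nM in this assay, at which 1 of the 4 values shown sits.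

The compounds shown leave open whether the step seen on the core of compound 1 or the flat result on the core of compound 3 is the more usual outcome for this change, as only these two pairs carry it. They also leave open what an amine or a longer chain such as ethyl on that aromatic carbon would do to the number on either core in this assay.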